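The source may hold more compounds than are shown below. What is called first, only, known or untested is meant among the compounds shown, and "the series" means these compounds.

Measured compounds:
compound 1 `CC(=O)Nc1cccc(-c2cn(Cc3cc(C(=O)O)cc(-c4ccccc4C(=O)O)c3)nn2)c1`, in an assay on cells for inhibition of ubiquitin carboxyl-terminal hydrolase isozyme L5 (Homo sapiens), read by fluorescence, with a stated time of 30 min (a lower number here means a stronger inhibitor, a higher number a weaker inhibitor), compound 1 gives 96200 nM;
compound 2 `NS(=O)(=O)Nc1ccc(-c2cn(Cc3cc(C(=O)O)cc(-c4ccccc4C(=O)O)c3)nn2)cc1`, in this assay compound 2 gives 84500 nM.

Among the measured compounds shown here, compound 2 holds the lower of the two numbers, and the only step measured so far, a 1.1-fold lower number from compound 1 to compound 2 (0.06 log units; within the scatter), is within the scatter, so compound 2 and compound 1 cannot be told apart on these data. Compound 3 `O=C(O)c1cc(Cn2cc(-c3cccnc3)nn2)cc(-c2ccccc2C(=O)O)c1` differs from compound 2 in one place: pyridin-3-yl in place of 4-(sulfamoylamino)phenyl on an aromatic carbon. For the measured compounds named here, no measured step swaps a group of this kind at this position; the single step from compound 1 to compound 2 exchanged one substituted phenyl for another and moved nothing beyond the scatter. Going by the values given here, on that basis no change beyond the scatter is expected in this assay for compound 3, with a wide range because the only guide is the flat step a 1.1-fold lower number from compound 1 to compound 2 (0.06 log units; within the scatter). Compound 3 is therefore estimated at 100000 nM, between 40000 nM and 250000 nM. The expected step is a 1.2-fold higher number from compound 2 to compound 3 (0.07 log units; within the scatter).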

Compound 3, half-maximal inhibitory concentration: 252000 nM
Beside the measured number, compound 3's estimate is 2.5-fold (0.40 log units) below it; the whole stated range lies below it.
By their numbers in this assay, from the lowest: compounds 2 and 1 (each within the scatter of the next); then compound 3.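

Placing pyridin-3-yl on this aromatic carbon gives a 3.0-fold higher number from compound 2 to compound 3 (0.47 log units; beyond the scatter) and a 2.6-fold higher number from compound 1 to compound 3 (0.42 log units; beyond the scatter) in this assay and so, unlike the exchange between the two substituted phenyl groups, moves the number beyond the scatter. The position is therefore not indifferent to its group, although both steps are modest and only this one replacement shows it. Nothing given here explains the rise in the number.

The change puts a ring nitrogen in place of a ring carbon and also drops the substituent of the phenyl, and the compounds shown do not separate these two differences. As far as these compounds go, it remains open whether an unsubstituted phenyl, or a phenyl carrying an amine or a carboxylic acid, would fall with compound 2 or with compound 3.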